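The compounds below may be only part of what the source reports. "The series", "measured", "known", "first", "only" and "open" are said of these compounds alone.

In an ADME assay on MRC5 cells (Homo sapiens), read by MTT assay, with a stated time of 72 h (a lower number here means a stronger inhibitor, a higher number a weaker inhibitor), compound 1 `Nc1nc(N)c2c(-c3ccsc3)cn([C@@H]3O[C@H](CO)[C@@H](O)[C@H]3O)c2n1` gives > 100000 nM, which is a limit and not a number. Compound 2 `Cc1nc(N)c2c(-c3ccco3)cn([C@@H]3O[C@H](CO)[C@@H](O)[C@H]3O)c2n1` gives the limit > 100000 nM. Compound 3 `Cc1nc(N)c2c(-c3cccs3)cn([C@@H]3O[C@H](CO)[C@@H](O)[C@H]3O)c2n1` also gives only a limit, > 100000 nM. All three therefore stand at the limit of > 100000 nM in this assay, at which 3 of the 3 values shown sit. Going by the values given here, the one measured step is a step that the two limits leave unreadable from compound 2 to compound 3, so it offers no size to carry over. Compound 4 `Cc1nc(N)c2c(-c3ccsc3)cn([C@@H]3O[C@H](CO)[C@@H](O)[C@H]3O)c2n1` differs from compound 3 by thiophen-3-yl in place of thiophen-2-yl on an aromatic carbon, with thiophen-3-yl in place of thiophen-2-yl on an aromatic carbon. Compound 1, which also carries thiophen-3-yl, shows the limit > 100000 nM. The expected change is a number no higher from compound 3 to compound 4 (the limit leaves the size open), with no shift beyond the scatter in either direction. For compound 4 the estimate is 100000 nM, within an expected range of 50000 nM to 200000 nM.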

Compound 4, half-maximal inhibitory concentration: > 100000 nM
Compound 4 was reported as a limit; the forecaster's own chance of this, stated with the estimate: 90%; the middle value lies on the limit itself.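

Compound 4 is also reported only as a limit, so its steps from compound 1, compound 2 and compound 3 cannot be read: the limit of > 100000 nM in this assay, at which 4 of the 4 values shown sit. The compounds shown leave open whether any of these changes alters the value in this assay at all.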